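The source may report more compounds than this note shows. Statements on the series, on what has been measured and on what is new or still open speak of the compounds shown alone.

Working notes on the series. Among the compounds with values here, in a functional assay on KBVIN cells (Homo sapiens) for antiproliferative activity, read by sulforhodamine B assay, with a stated time of 3 days (a lower number here means a stronger inhibitor of growth, a higher number a weaker inhibitor of growth), compound 1 `O=C(c1cccc(Nc2ncc(F)c(Nc3ccc(F)cc3)n2)c1)N1CCCCC1` gives 13800 nM, the highest of the three numbers measured so far, though compound 3 `O=C(Nc1ccccn1)c1cccc(Nc2ncc(F)c(Nc3ccc(F)cc3)n2)c1`, at 13700 nM, lies within the scatter of it. Within the data shown here, compound 2 `COc1ccc(N2CCN(C)CC2)cc1Nc1ncc(F)c(Nc2ccc(F)cc2)n1` gives 910 nM, well below compound 1, but it differs from compound 1 in more than one place, so no single step is known for that pair. Compound 4 `COc1cc(NC(=O)c2cccc(Nc3ncc(F)c(Nc4ccc(F)cc4)n3)c2)cc(OC)c1` has not yet been measured; it differs from compound 1 by (3,5-dimethoxyphenyl)amino in place of piperidin-1-yl on a carbonyl carbon. Among the measured compounds shown here, one measured step bears on this: a 1.0-fold lower number from compound 1 to compound 3 (0.00 log units; within the scatter), which likewise replaced piperidin-1-yl on a carbonyl carbon. On that basis the move is expected to be a 1.2-fold lower number from compound 1 to compound 4 (0.06 log units; within the scatter). Compound 4 is therefore estimated at 12000 nM in this assay, within 4000 nM to 36000 nM.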

Compound 4, concentration for 50% growth inhibition: 12700 nM
Compound 4: the middle estimate sits 1.1-fold (0.02 log units) below what was measured; low and high end bracket the measured number.
By their numbers in this assay, from the lowest: compound 2; then compounds 4, 3 and 1 (each within the scatter of the next).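

In this assay, the larger (3,5-dimethoxyphenyl)amino on the carbonyl carbon leaves the number unmoved against piperidin-1-yl, with a 1.1-fold lower number from compound 1 to compound 4 (0.04 log units; within the scatter), and 3,5-dimethoxyphenyl on the amide-type nitrogen does the same against pyridin-2-yl, with a 1.1-fold lower number from compound 3 to compound 4 (0.03 log units; within the scatter). Across compounds 1, 3 and 4, a non-aromatic ring, a nitrogen-containing aromatic ring and a carbon-only aromatic ring with two methoxy groups thus give values within the scatter of one another. No measurement offers an explanation for this. On these data alone, whether a morpholin-4-yl or a carboxylic acid in place of these groups would shift the number remains open.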